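Trifluoromethyl for nitro: working notes on compound 4

The source may report more compounds than this note shows. Statements on the series, on what has been measured and on what is new or still open speak of the compounds shown alone.

compound 1 `Cc1ccc(S(=O)(=O)N2C(=O)C(C)OC23C=CC(=O)C=C3)cc1` gives > 10000 nM as a limit
compound 2 `O=C1C=CC2(C=C1)OCC(=O)N2S(=O)(=O)c1ccc([N+](=O)[O-])cc1` gives > 10000 nM as a limit
compound 3 `O=C1C=CC2(C=C1)OCC(=O)N2S(=O)(=O)c1ccc(F)c(F)c1` gives 30 nM as a number

Among the measured compounds shown here, all three were read as half-maximal inhibitory concentration in a functional assay on HeLa cells (Homo sapiens) for inhibition, read by sulforhodamine B assay, with a stated time of 74 h (a higher number here means a weaker inhibitor, a lower number a stronger inhibitor), and only compound 3 has a number so far. Compound 2 stands at > 10000 nM in this read-out, which is a limit and not a number. For the measured compounds named here, the series so far shows the limit of > 10000 nM in this assay, at which 2 of the 3 values shown sit, and compound 1 sits there too.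

Compound 4 `O=C1C=CC2(C=C1)OCC(=O)N2S(=O)(=O)c1ccc(C(F)(F)F)cc1` has trifluoromethyl in place of nitro on an aromatic carbon, para to a large group, with trifluoromethyl in place of nitro on an aromatic carbon as the full count of the change.

Going by the values given here, no measured step covers this change. A move toward stronger inhibition is expected, though its size is loose. This expectation rests on compound 3, which gives 30 nM on the core of compound 2. Against that, compound 1 and compound 2 both remain at the limit.

The expected step is an at least 33-fold lower number from compound 2 to compound 4 (1.52 log units; beyond the scatter) as an estimate. The estimate for compound 4 is 300 nM with an expected range from 30 nM to 5000 nM in this assay as the read-out.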

Compound 4, half-maximal inhibitory concentration: 770 nM
Compound 4: middle estimate off by 2.6-fold (0.41 log units), on the low side, within the range that was stated.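

Trifluoromethyl in place of nitro on an aromatic carbon, para to a large group, gives an at least 12-fold lower number from compound 2 to compound 4 (1.11 log units; beyond the scatter) in this assay. Among the compounds shown here, this is the only measured step, and it shows that a change at this one place, on an otherwise unchanged core, is enough to bring compound 2 off its limit to a measurable value. As far as these compounds go, the true size of the step stays unknown because the value of compound 2 is a limit and not a number: the limit of > 10000 nM in this assay, at which 2 of the 4 values shown sit.

The compounds shown leave open how the read-out responds to other groups at this place, such as an amine, a carboxylic acid or a single fluorine. They also do not separate the loss of nitro from the arrival of trifluoromethyl as the source of the step.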